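The source may hold more compounds than are shown below. What is called first, only, known or untested is meant among the compounds shown, and "the series" means these compounds.

In a functional assay on CCRF-CEM cells (Homo sapiens) for antiproliferative activity, read by cell counting, with a stated time of 72 h (on this read-out higher numbers stand for weaker inhibition and lower numbers for stronger inhibition), compound 3 (`C#C[C@@]1(O)[C@@H](CO)O[C@@H](n2cc(-c3ccco3)c3c(N)ncnc32)[C@@H]1O`) stands highest of the three measured compounds at 17000 nM and is the weakest of them. Compound 1 (`C#C[C@@]1(O)[C@@H](CO)O[C@@H](n2cc(Br)c3c(N)ncnc32)[C@@H]1O`) gives 30 nM and compound 2 (`C#C[C@@]1(O)[C@@H](CO)O[C@@H](n2cc(I)c3c(N)ncnc32)[C@@H]1O`) gives 120 nM on the same read-out. Compound 4 (`C#C[C@@]1(O)[C@@H](CO)O[C@@H](n2cc(C(F)(F)F)c3c(N)ncnc32)[C@@H]1O`) differs from compound 3 by one change (trifluoromethyl in place of furan-2-yl on an aromatic carbon): trifluoromethyl in place of furan-2-yl on an aromatic carbon.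

Three measured steps at this same place bear on it. The two steps into furan-2-yl are large (a 570-fold higher number from compound 1 to compound 3 (2.75 log units; beyond the scatter)) and (a 140-fold higher number from compound 2 to compound 3 (2.15 log units; beyond the scatter)), while iodo in place of bromo is modest (a 4.0-fold higher number from compound 1 to compound 2 (0.60 log units; beyond the scatter)). Trifluoromethyl, like bromo and iodo, has no ring, so compound 4 is expected to lie nearer compound 1 (30 nM) and compound 2 (120 nM) than compound 3. The series holds no trifluoromethyl value, so this placing is uncertain. A large step toward stronger inhibition is expected in this assay (a 57-fold lower number from compound 3 to compound 4 (1.75 log units; beyond the scatter)). The estimate for compound 4 is 300 nM with an expected range of 50 nM to 3000 nM on this read-out.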

Compound 4, half-maximal inhibitory concentration: 360 nM
Compound 4: middle estimate off by 1.2-fold (0.08 log units), on the low side; the range from low to high includes it.
By their numbers in this assay, from the lowest: compound 1; then compound 2; then compound 4; then compound 3.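

In this assay, a large loss is not general to replacing the halogens at this aromatic carbon: ringless trifluoromethyl recovers much of the activity lost with furan-2-yl, with a 47-fold lower number from compound 3 to compound 4 (1.67 log units; beyond the scatter). The ringless groups still separate at this position, as trifluoromethyl gives a 3.0-fold higher number from compound 2 to compound 4 (0.48 log units; beyond the scatter) and a 12-fold higher number from compound 1 to compound 4 (1.08 log units; beyond the scatter), so the order among them runs bromo, then iodo, then trifluoromethyl. No measurement at hand accounts for these gaps.

Furan-2-yl is the only ring at this position here, so one compound cannot show whether the large loss belongs to that group or extends to aromatic rings in general. A phenyl ring, a chlorine atom or a nitrile on the same carbon of the shared core would test how far each pattern holds.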